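Swapping bromo for methoxy on a second core

A few compounds are considered here, and "the series" means these few. Any claim that something is new, unique, unknown or untested is made for them only; others in the source may bear on it.

Compound 1 `O=C(Nc1ccc(Oc2ccnc3[nH]ccc23)cc1)c1cc2cccnc2n(-c2ccc(Br)cc2)c1=O` and compound 2 `COc1ccc(-n2c(=O)c(C(=O)Nc3ccc(Oc4ccnc5[nH]ccc45)cc3)cc3cccnc32)cc1` share one core; compound 3 `Cn1ccc2c(Oc3ccc(NC(=O)c4cc5cccnc5n(-c5ccc(Br)cc5)c4=O)cc3F)ccnc21` and compound 4 `COc1ccc(-n2c(=O)c(C(=O)Nc3ccc(Oc4ccnc5c4ccn5C)c(F)c3)cc3cccnc32)cc1` share another, and the difference between the two cores is not broken down here. In a functional assay on A549 cells (Homo sapiens) for antiproliferative activity, read by MTT assay, with a stated time of 72 h (a lower number here means a stronger inhibitor, a higher number a weaker inhibitor), compound 1 gives 280 nM, compound 2 gives 930 nM and compound 3 gives 390 nM. The change from compound 1 to compound 2 is methoxy in place of bromo on an aromatic carbon and brings a 3.3-fold higher number from compound 1 to compound 2 (0.52 log units; beyond the scatter). The same change, (methoxy in place of bromo on an aromatic carbon), is made from compound 3 to compound 4, at the same place on both cores. The step expected for compound 4 is a 3.3-fold higher number from compound 3 to compound 4 (0.52 log units; beyond the scatter), because the matching change gives a 3.3-fold higher number from compound 1 to compound 2 (0.52 log units; beyond the scatter), though that rests on a single measured pair. Compound 4 is therefore estimated at 1300 nM, with a likely range from 600 nM to 2800 nM.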

Compound 4, half-maximal inhibitory concentration: 2750 nM
For compound 4 the middle estimate is 2.1-fold (0.33 log units) below the measured one; the measured number falls inside the stated range.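

Replacing bromo with methoxy again gives a weaker compound on the second core, with a 7.1-fold higher number from compound 3 to compound 4 (0.85 log units; beyond the scatter) in this assay. The step runs the same way on both cores, and its size does not differ beyond what scatter allows: the same change on two cores in this assay, a 3.3-fold higher number (0.52 log units; beyond the scatter) from compound 1 to compound 2 and a 7.1-fold higher number (0.85 log units; beyond the scatter) from compound 3 to compound 4, 2.1-fold (0.33 log units) apart, within the scatter of two such steps

This supports carrying the change between these two cores, but it rests on just two pairs in one assay, so it shows neither that the change would behave alike on other cores nor why methoxy gives the higher number.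

The compounds shown leave open how an amine, a carboxylic acid or a longer chain such as butoxy would compare at this place. Also open is what the difference between the two cores does alone, as no pair shown changes only that.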